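Chloro on the benzyl ring of the sulfonamide imide series

A few compounds are considered here, and "the series" means these few. Any claim that something is new, unique, unknown or untested is made for them only; others in the source may bear on it.

Three compounds of this series carry a measurement in an assay on isolated protein for inhibition of lysosomal alpha-glucosidase (Rattus norvegicus), read by colorimetric assay (on this read-out higher numbers stand for weaker inhibition and lower numbers for stronger inhibition), so far. Compound 1 `Cc1ccc(S(=O)(=O)Nc2ccc3c(c2)C(=O)N(Cc2ccccc2F)C3=O)cc1` gives 195000 nM in this assay. Compound 3 `O=C1c2ccc([N+](=O)[O-])cc2C(=O)N1CCNc1ccccc1`, which carries a nitro group and an anilinoethyl chain instead of the sulfonamide and benzyl groups, gives 111000 nM in this assay. For compound 2 `Cc1ccc(S(=O)(=O)Nc2ccc3c(c2)C(=O)N(Cc2ccccc2)C3=O)cc1` this assay returns only a limit, > 200000 nM, so its position is known as a range rather than as a number. For the measured compounds named here, the one measured step that bears on the benzyl ring, an at least 1.0-fold higher number from compound 1 to compound 2 (0.01 log units; that floor lies within the scatter), ends at that limit of > 200000 nM in this assay, at which 1 of the 3 values shown sits, and therefore gives only a floor for the change.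

Compound 4 `Cc1ccc(S(=O)(=O)Nc2ccc3c(c2)C(=O)N(Cc2ccc(Cl)cc2)C3=O)cc1` differs from compound 2 in one place: chloro in place of hydrogen on an aromatic carbon. Going by the values given here, no measured step introduces a chloro on this ring, and the only change on the same ring, fluoro to hydrogen, did not move the number beyond the scatter. No step beyond the scatter is therefore expected for compound 4 in this assay, and the estimated step is a step that the limit leaves unreadable from compound 2 to compound 4. Compound 4 is accordingly expected to give about 250000 nM in this assay, within a range from 110000 nM to 700000 nM, with a real chance that this assay again reports only a limit.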

Compound 4, half-maximal inhibitory concentration: 188000 nM
Beside the measured number, compound 4's estimate is 1.3-fold (0.12 log units) above it, within the range that was stated.
By their numbers in this assay, from the lowest: compounds 3, 4 and 1 (each within the scatter of the next). At a limit, above all of these: compound 2.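

Chloro on the benzyl ring, para to a large group, gives a second halogen comparison on this ring: in this assay, the change from 2-fluorophenyl to 4-chlorophenyl gives a 1.0-fold lower number from compound 1 to compound 4 (0.02 log units; within the scatter). Thus, the two halogen-bearing compounds cannot be told apart, and neither the kind of halogen nor its place on the ring can be separated in this pair, since both changed together. Chloro in place of hydrogen gives an at least 1.0-fold lower number from compound 2 to compound 4 (0.02 log units; that floor lies within the scatter), which is a floor and not a size, and the real step cannot be read because compound 2 stands at a limit in this assay: the limit of > 200000 nM in this assay, at which 1 of the 4 values shown sits.

Going by these compounds, whether any group on this ring can move the number beyond the scatter stays open, for example an amine or a carboxylic acid on the ring, or a longer chain carrying the ring in place of the benzyl group. On these data alone, compound 3 differs from the sulfonamide compounds in more than one place, so the contribution of the sulfonamide itself also remains open.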